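Triazole nitrogen substitution in the dichlorophenyl amide series

The compounds below may be only part of what the source reports. "The series", "measured", "known", "first", "only" and "open" are said of these compounds alone.

In an assay on 32D cells for inhibition of interleukin-15 (Mus musculus), read by resazurin assay, with stated times of 30 min and 2.5 days, in the presence of a further agent that is not named here (on this read-out higher numbers stand for weaker inhibition and lower numbers for stronger inhibition), compound 1 `CCOC(CCn1c(Cc2nn(C)c(=O)c3ccccc23)nnc1SCC(=O)Nc1ccc(Cl)cc1Cl)OCC` returns only a limit, > 30000 nM, not a number. Going by the values given here, compound 2 `Cn1nc(Cc2nnc(SCCCCCCCC(=O)Nc3ccc(Cl)cc3Cl)[nH]2)c2ccccc2c1=O` gives 3500 nM in this assay, and this is the only numerical value shown for the pair; the other value is the limit of > 30000 nM in this assay, at which 1 of the 2 values shown sits. Among the compounds with values here, no step between measured compounds can be computed, since compound 1 and compound 2 differ in more than one place.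

Compound 3 `Cn1nc(Cc2nnc(SCCCCCCCC(=O)Nc3ccc(Cl)cc3Cl)n2CCC(=O)O)c2ccccc2c1=O` differs from compound 2 by 2-carboxyethyl in place of hydrogen on an aromatic nitrogen. With no measured step of this kind in hand, the expectation is a modest loss, a step from compound 2 to compound 3 of about a 2.3-fold higher number from compound 2 to compound 3 (0.36 log units; beyond the scatter) in this assay, beyond the usual scatter but not to the point of a limit. Compound 3 is thus estimated at 8000 nM, with a range from 2500 nM to 30000 nM.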

Compound 3, half-maximal inhibitory concentration: > 30000 nM
Compound 3 was reported as a limit; the forecaster's own chance of this, stated with the estimate: 30%; at least 3.7-fold (0.57 log units) between middle value and limit.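

Replacing hydrogen with 2-carboxyethyl on the aromatic nitrogen gives an at least 8.5-fold higher number from compound 2 to compound 3 (0.93 log units; beyond the scatter) in this assay. Going by these compounds alone, this is the first change that can be read at one place, and it shows that this nitrogen, two ring bonds from the ring nitrogen, does not accept this group without a loss beyond the scatter. Compound 3 gives only a limit, so the step sets a lower bound on the loss, and compound 2 stays the only compound with a number: the limit of > 30000 nM in this assay, at which 2 of the 3 values shown sit.

The compounds shown leave open whether the loss follows from the carboxylic acid itself or from any chain on this nitrogen. A methyl group, an ethyl ester or an aminopropyl chain at this place would separate those two readings.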